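The compounds below may be only part of what the source reports. "The series", "measured", "known", "first", "only" and "open" are said of these compounds alone.

Among the compounds with values here, compound 2 `CCCn1c(=O)c2nc(-c3cccn3C)[nH]c2n(CCC)c1=O` gives the highest of the two numbers so far in an assay on cell membranes for binding affinity to adenosine receptor A1 (Cavia porcellus), read by radioligand binding; on this read-out lower numbers stand for stronger inhibition and higher numbers for weaker inhibition: compound 2 gives 140 nM, while compound 1 `CCCn1c(=O)c2nc([C@H]3CC4C=CC3C4)[nH]c2n(CCC)c1=O` gives 3.4 nM. Within the data shown here, the step of a 41-fold higher number from compound 1 to compound 2 (1.61 log units; beyond the scatter) is the only measured step, and it shows that exchanging the bridged bicyclic group on the shared core for the small aromatic ring costs a great deal of affinity. Compound 3 `CCCn1c(=O)c2nc(CC3CC3)[nH]c2n(CCC)c1=O` is the next member; the change is cyclopropylmethyl in place of 1-methyl-1H-pyrrol-2-yl on an aromatic carbon. Among the measured compounds shown here, no measured step covers this exact exchange. For the measured compounds named here, the one measured step bears on it indirectly: a non-aromatic carbon-only ring on that carbon gave a far lower number than the aromatic ring of compound 2, so for compound 3 a move back toward a lower number is expected, though cyclopropylmethyl is smaller than the group of compound 1, so a step of a 4.7-fold lower number from compound 2 to compound 3 (0.67 log units; beyond the scatter) is estimated rather than the full reversal. Compound 3 is expected at 30 nM, within 6 nM to 150 nM in this assay.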

Compound 3, inhibition constant: 120 nM
For compound 3 the middle estimate is 4.0-fold (0.60 log units) below the measured one; the range from low to high includes it.
By their numbers in this assay, from the lowest: compound 1; then compounds 3 and 2 (each within the scatter of the next).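

In this assay the exchange of 1-methyl-1H-pyrrol-2-yl for cyclopropylmethyl on this aromatic carbon gives a 1.2-fold lower number from compound 2 to compound 3 (0.07 log units; within the scatter) and leaves the two groups indistinguishable at this position. Replacing the aromatic ring with a non-aromatic ring of carbon only is therefore not enough on its own to reach the number of compound 1, as the comparison with the bridged bicyclic group shows: a 35-fold higher number from compound 1 to compound 3 (1.55 log units; beyond the scatter) remains between these two compounds. Nothing available here bears on the reason for either step.

On these data alone, it remains open which feature of the bridged bicyclic group of compound 1 goes with its low number. As far as these compounds go, the effect of an amine, a carboxylic acid or a longer alkyl chain on this aromatic carbon also remains open.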